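Adding a Second Chloro Group: Expected Growth Inhibition

The source may report more compounds than this note shows. Statements on the series, on what has been measured and on what is new or still open speak of the compounds shown alone.

Measured compounds:
Compound 1 `ClCc1ccc(Cn2cnc3c(Cl)ncnc32)cc1` gives 6600 nM
Compound 2 `ClCc1cccc(Cn2cnc3ncnc(Cl)c32)c1` gives 15800 nM
Compound 3 `ClCc1ccc(Cn2cnc3c(Cl)nc(Cl)nc32)cc1` gives 18600 nM

These three values come from a functional assay on OVCAR-4 cells (Homo sapiens) for cytotoxicity, read by sulforhodamine B assay, with a stated time of 48 h; on this read-out lower numbers stand for stronger inhibition of growth and higher numbers for weaker inhibition of growth. Compound 1 and compound 3 differ in one place, (chloro in place of hydrogen on an aromatic carbon), and this change gave a 2.8-fold higher number from compound 1 to compound 3 (0.45 log units; beyond the scatter). Compound 2 has the same atoms as compound 1 joined differently; the difference between the two cores is not broken down here. The values of compound 2 and compound 3 lie within the scatter of each other, so no order between them is claimed.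

Compound 4 `ClCc1cccc(Cn2cnc3nc(Cl)nc(Cl)c32)c1` has not been measured. It differs from compound 2 by chloro in place of hydrogen on an aromatic carbon, which is the same change as that from compound 1 to compound 3, at the same surroundings. A step of similar size is expected here because of a 2.8-fold higher number from compound 1 to compound 3 (0.45 log units; beyond the scatter). The expected step is a 2.8-fold higher number from compound 2 to compound 4 (0.44 log units; beyond the scatter), resting on that single earlier example only. Compound 4 is therefore estimated at 44000 nM, with a range from 20000 nM to 100000 nM.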

Compound 4, concentration for total growth inhibition: 2950 nM
For compound 4 the middle estimate is 15-fold (1.17 log units) above the measured one, outside the stated range (below it).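

Putting a chloro group in place of hydrogen on the aromatic carbon between two ring nitrogen atoms strengthened growth inhibition on the core of compound 2, giving a 5.4-fold lower number from compound 2 to compound 4 (0.73 log units; beyond the scatter), since a lower number stands for stronger inhibition. On the core of compound 1, the same change had weakened it, so in this series the step did not carry from one core to the other, in direction or in size: the same change on two cores in this assay, a 2.8-fold higher number (0.45 log units; beyond the scatter) from compound 1 to compound 3 and a 5.4-fold lower number (0.73 log units; beyond the scatter) from compound 2 to compound 4, 15-fold (1.18 log units) apart, beyond the scatter of two such steps. Going by these compounds alone, these are only two pairs, so they show that the core matters but not why the two steps part ways or what the change would do on a further core.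

The compounds shown hold only hydrogen or chloro on that ring carbon, which leaves open how an amine or a methoxy group would behave there on either core. As far as these compounds go, all of them also carry a chloromethyl group, so what a plain methyl or a hydroxymethyl group would do in its place also stays open.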